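Fluoro to methoxycarbonyl on the aryl ether arm

This account rests on a few compounds, and the source may have more. Where it says the series, first, only, none or still open, it means among the compounds named here.

Measured so far in a functional assay on MCF7 cells (Homo sapiens) for antiproliferative activity, read by MTT assay, with a stated time of 48 h; on this read-out higher numbers stand for weaker inhibition and lower numbers for stronger inhibition:
compound 1 `Nc1ccc(OCc2cn(-c3cc(=O)oc4ccc(Br)cc34)nn2)cc1` gives 2040 nM
compound 2 `O=c1cc(-n2cc(COc3ccc(Br)cc3)nn2)c2cc(Br)ccc2o1` gives 1920 nM
compound 3 `O=c1cc(-n2cc(COc3ccc(F)cc3)nn2)c2cc(Br)ccc2o1` gives 7000 nM

Compound 3 holds the highest number of the three. The two steps that reach it are a 3.4-fold higher number from compound 1 to compound 3 (0.54 log units; beyond the scatter) and a 3.6-fold higher number from compound 2 to compound 3 (0.56 log units; beyond the scatter), both beyond the scatter, whereas a 1.1-fold lower number from compound 1 to compound 2 (0.03 log units; within the scatter). So on this small set the fluoro case sits apart, and the amino and bromo cases sit together.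

Compound 4 `COC(=O)c1ccc(OCc2cn(-c3cc(=O)oc4ccc(Br)cc34)nn2)cc1` keeps the shared core and changes the same aromatic carbon: methoxycarbonyl in place of fluoro on an aromatic carbon. The relevant comparisons are the two that replace fluoro on that carbon, from compound 3 back to compound 1 and to compound 2; each moved the number down by a modest amount. No ester has been measured in this series, so the direction is read from those two swaps only, and the size is taken as similar to them rather than larger.

Compound 4 is therefore expected to land at 2500 nM, with a plausible range from 900 nM to 7000 nM. The expected step is a 2.8-fold lower number from compound 3 to compound 4 (0.45 log units; beyond the scatter), modest and downward, with the upper end of the range allowing that the change may do nothing beyond the scatter.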

Compound 4, half-maximal inhibitory concentration: 3130 nM
For compound 4 the middle estimate is 1.3-fold (0.10 log units) below the measured one; the range from low to high includes it.
By their numbers in this assay, from the lowest: compounds 2, 1 and 4 (each within the scatter of the next); then compound 3.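

In this assay, methoxycarbonyl on the aromatic carbon para to a large group gives a 2.2-fold lower number from compound 3 to compound 4 (0.35 log units; beyond the scatter) and is thus a third replacement of fluoro that lowers the number, here with a group of more heavy atoms that adds hydrogen-bond acceptors. The comparisons with the other two replacements, a 1.6-fold higher number from compound 2 to compound 4 (0.21 log units; within the scatter) and a 1.5-fold higher number from compound 1 to compound 4 (0.19 log units; within the scatter), both lie within the scatter, so compounds 1, 2 and 4 form one cluster with no order among them, while compound 3 stands apart from all three. No measurement here bears on why the fluoro case separates from the others.

Still open, from the compounds shown here alone, is whether chloro or methyl at this carbon would fall with compound 3 or with the cluster, which would show how particular the fluoro result is. The carboxylic acid, the hydroxyl and the longer ethyl ester at the same carbon would show whether the cluster extends to other oxygen-bearing groups or whether its numbers shift beyond the scatter.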